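The source may hold more compounds than are shown below. What is called first, only, known or untested is meant among the compounds shown, and "the series" means these compounds.

Measured compounds in the series:

- compound 1, `Cc1nnc(SCC(=O)N/N=c2/scc(-c3ccc(Cl)cc3)n2-c2ccccc2)s1`: 34.1%
- compound 2, `Cc1ccc(-c2cs/c(=N/NC(=O)CSc3nnnn3-c3ccccc3)n2-c2ccccc2)cc1`: 28.5%
- compound 3, `O=C(CSc1nnnn1-c1ccccc1)N/N=c1/scc(-c2ccc(F)cc2)n1-c1ccccc1`: 35.8%

In a functional assay on C6 cells (Rattus norvegicus) for cytotoxicity, read by MTT assay, with a stated time of 24 h, tested at 100 ug/mL (on this read-out lower numbers stand for a stronger effect and higher numbers for a weaker effect at the one concentration tested), compound 3 gives 35.8%, the highest of the three numbers, with compound 1 nearest and compound 2 furthest; both gaps lie within the scatter, so no order among the three can be claimed.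

Compound 4, `O=C(CSc1nnnn1-c1ccccc1)N/N=c1/scc(-c2ccc(Cl)cc2)n1-c1ccccc1`, remains to be measured. It differs from compound 3 as follows:

chloro in place of fluoro on an aromatic carbon

Within the data shown here, the only measured step that touches the same aromatic carbon is a number 7.3 percentage points higher from compound 2 to compound 3 (within the scatter), a change from methyl to fluoro, and it stayed within the scatter. Among the measured compounds shown here, no measured pair shows chloro in place of fluoro on a shared core; compound 1 carries chloro but differs in its core too, so its value can only be noted, not used as a step. The expectation for a number 1.8 percentage points lower from compound 3 to compound 4 (within the scatter) is therefore a step of no size beyond the scatter. For compound 4 the estimate in this assay is 34%, expected to fall between 23% and 46%.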

Compound 4, a percentage reported as activity, at one concentration (the size of the read-out at that concentration, not a potency): 54.3%
For compound 4 the middle estimate is 20.3 percentage points below the measured one, outside the stated range (above it).
By their numbers in this assay, from the lowest: compounds 2, 1 and 3 (each within the scatter of the next); then compound 4.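

In this assay, among these compounds, the change from 4-fluorophenyl to 4-chlorophenyl gives a number 18.5 percentage points higher from compound 3 to compound 4 (beyond the scatter) and is the first step on this aromatic carbon to pass the scatter, towards a weaker effect at the one concentration tested. Chloro in place of methyl runs the same way (a number 25.8 percentage points higher from compound 2 to compound 4 (beyond the scatter)), while methyl to fluoro gave only a number 7.3 percentage points higher from compound 2 to compound 3 (within the scatter) on the same carbon. Chloro alone does not set the value, as the group on the sulfur also counts with chloro held fixed (a number 20.2 percentage points higher from compound 1 to compound 4 (beyond the scatter)), and no measurement shown here offers an explanation for either step.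

From the compounds shown here alone, whether the chloro step depends on the 1-phenyl-1H-tetrazol-5-yl group remains open, as the 5-methyl-1,3,4-thiadiazol-2-yl group appears here only with chloro. Bromo, methoxy or an amine on this aromatic carbon would show whether chloro stands alone in this series.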